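A few compounds are considered here, and "the series" means these few. Any claim that something is new, unique, unknown or untested is made for them only; others in the source may bear on it.

Measured in a functional assay on MDA-MB-231 cells (Homo sapiens) for cytotoxicity, read by MTT assay, with a stated time of 72 h; a higher number here means a weaker inhibitor, a lower number a stronger inhibitor:
- compound 1 `CN(C)CCCCCn1c2c(c3ccccc31)C(=O)c1c[n+]([O-])c3ccccc3c1C2=O`: 240 nM
- compound 2 `O=C1c2c[n+]([O-])c3ccccc3c2C(=O)c2c1c1ccccc1n2Cc1cn([C@H]2O[C@H](CO)[C@@H](O)[C@H]2O)nn1`: 1700 nM
- compound 3 `O=C1c2c[n+]([O-])c3ccccc3c2C(=O)c2c1c1ccccc1n2Cc1cn([C@@H]2C[C@H](O)[C@@H](CO)O2)nn1`: 130 nM

Compound 1 sits in the middle of these three numbers. Its value lies within the scatter of compound 3, while compound 2 has a higher number, beyond the scatter.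

Compound 4 `CN1CCN(CCCCn2c3c(c4ccccc42)C(=O)c2c[n+]([O-])c4ccccc4c2C3=O)CC1` keeps the core of compound 1 and changes only the end of the side chain, with 4-methylpiperazin-1-yl in place of (dimethylamino)methyl on a saturated chain carbon, four bonds along the chain from an aromatic nitrogen.

For the measured compounds named here, no measured step makes this change or anything close to it. Going by the values given here, the only step available is a 13-fold lower number from compound 2 to compound 3 (1.12 log units; beyond the scatter), a swap of hydrogen for hydroxy on a saturated ring carbon, in a different side chain. It offers no direction for compound 4, but it shows that a small edit away from the core can move the number a long way, so the range must stay wide.

In this assay, the estimated change is small, within the scatter: a 1.3-fold higher number from compound 1 to compound 4 (0.10 log units; within the scatter). The expected value for compound 4 is 300 nM, with an estimated range from 100 nM to 900 nM.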

Compound 4, half-maximal inhibitory concentration: 110 nM
The estimate for compound 4 lay 2.7-fold (0.44 log units) above the measured number; the range from low to high includes it.
By their numbers in this assay, from the lowest: compounds 4, 3 and 1 (each within the scatter of the next, the first and the last beyond it); then compound 2.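

In this assay, putting 4-methylpiperazin-1-yl in place of (dimethylamino)methyl, on a saturated chain carbon, four bonds along the chain from an aromatic nitrogen, gives a 2.2-fold lower number from compound 1 to compound 4 (0.34 log units; beyond the scatter). For the compounds shown here, this is the first measured change at the end of this side chain, and it shows that a larger end group carrying a six-membered ring keeps the number low and even lowers it modestly, by a margin beyond the scatter. No measurement shown explains why the number moves.

The step cannot say whether the ring itself or the different way the nitrogens are placed along the chain matters more. Going by these compounds, whether a morpholin-4-yl or piperidin-1-yl group at this place, or a longer chain leading to the 4-methylpiperazin-1-yl group, would give a similar number remains open.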